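Compound 3 to compound 4: formyl to acetyl

This account rests on a few compounds, and the source may have more. Where it says the series, first, only, none or still open, it means among the compounds named here.

compound 1 `O=C(N[C@H]1CN(S(=O)(=O)c2ccccc2)C[C@@H]1C(=O)N[C@H]1CCCNC1)c1cc(-c2ccccc2Cl)on1`: 1.9
compound 2 `CN1CCC[C@H](NC(=O)[C@H]2CN(S(=O)(=O)c3ccccc3)C[C@@H]2NC(=O)c2cc(-c3ccccc3Cl)on2)C1`: 3.1
compound 3 `O=CN1CCC[C@H](NC(=O)[C@H]2CN(S(=O)(=O)c3ccccc3)C[C@@H]2NC(=O)c2cc(-c3ccccc3Cl)on2)C1`: 3.1

These three compounds were compared in a physicochemical assay for lipophilicity, measured as octanol-water partition, at pH 7.4; a lower number here means a more polar compound, a higher number a more lipophilic compound. Compound 3 gives 3.1, level with compound 2 at 3.1, and the two together hold the highest of the three numbers. Compound 4 `CC(=O)N1CCC[C@H](NC(=O)[C@H]2CN(S(=O)(=O)c3ccccc3)C[C@@H]2NC(=O)c2cc(-c3ccccc3Cl)on2)C1` has not yet been measured. It departs from compound 3 by methyl in place of hydrogen on a carbonyl carbon, or formyl to acetyl.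

Among the measured compounds shown here, no measured step changes that exact place. The nearest evidence is no change at the digits printed from compound 2 to compound 3 (within the scatter), with formyl in place of methyl on an amine nitrogen in a ring. The other two steps are large, a number 1.20 log units higher from compound 1 to compound 2 (beyond the scatter) and a number 1.20 log units higher from compound 1 to compound 3 (beyond the scatter), but each replaces the hydrogen on that amine nitrogen itself, which compound 4 leaves untouched. A large step of that kind is therefore not expected in this assay, and the flat step to compound 3 from compound 2 points to little movement. The expected step is a number 0.10 log units higher from compound 3 to compound 4 (within the scatter), small, slightly upward and within the scatter. For compound 4 the estimated value is 3.2, with an expected range from 2.8 to 3.6.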

Compound 4, distribution coefficient: 3.5
Compound 4: middle estimate off by 0.30 log units, on the low side, within the range that was stated.
By their numbers in this assay, from the lowest: compound 1; then compounds 2 and 3 (each within the scatter of the next); then compound 4.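

In this assay, the carbonyl carbon on the ring's amide-type nitrogen proves to be a place where a single added methyl registers: there is a number 0.40 log units higher from compound 3 to compound 4 (beyond the scatter), although the earlier swap on that nitrogen gave no change at the digits printed from compound 2 to compound 3 (within the scatter) and so had not separated formyl from methyl. Acetyl does separate from methyl, with a number 0.40 log units higher from compound 2 to compound 4 (beyond the scatter), and replacing the hydrogen on the amine nitrogen with acetyl gives a number 1.60 log units higher from compound 1 to compound 4 (beyond the scatter), which leaves compound 4 alone at the top of these four compounds, since its steps to all three others are printed as beyond the scatter. Nothing available here accounts for the step from formyl to acetyl.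

The compounds shown leave open whether a longer chain on that carbonyl carbon, such as propanoyl or butanoyl, would carry the number further up or would level off. They also leave open how a carbonyl carbon bearing an amine or a methoxy group in place of the methyl would read in this assay, and whether the same methyl step would recur on a different core.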